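Three aryl groups so far, a fourth one awaited

The compounds below may be only part of what the source reports. "The series", "measured", "known", "first", "only" and "open" are said of these compounds alone.

Measured in a functional assay on BJAB cells (Homo sapiens) for antiproliferative activity, with a stated time of 4 days; on this read-out higher numbers stand for an effect only at larger amounts of compound and lower numbers for an effect already at smaller amounts:
Compound 1 `Cc1nn(-c2nc(-c3ccc(Cl)c(Cl)c3)c(SC(C)C)s2)c(C(=O)O)c1-c1cncc(C#N)c1` gives 20000 nM.
Compound 2 `Cc1nn(-c2nc(-c3ccc(Cl)c(Cl)c3)c(SC(C)C)s2)c(C(=O)O)c1-c1cnccn1` gives 14000 nM.
Compound 3 `Cc1cccc(-c2c(C)nn(-c3nc(-c4ccc(Cl)c(Cl)c4)c(SC(C)C)s3)c2C(=O)O)c1` gives 17000 nM.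

Compound 3 stands second highest of these three numbers, yet all three lie close together: a 1.2-fold lower number from compound 1 to compound 3 (0.07 log units; within the scatter) and a 1.2-fold higher number from compound 2 to compound 3 (0.08 log units; within the scatter), both within the scatter, as is a 1.4-fold lower number from compound 1 to compound 2 (0.15 log units; within the scatter). Swapping the aryl group on the shared core has so far left this assay essentially unchanged.

Compound 4 `CNc1cc(-c2c(C)nn(-c3nc(-c4ccc(Cl)c(Cl)c4)c(SC(C)C)s3)c2C(=O)O)ccn1` continues this series with 2-(methylamino)pyridin-4-yl in place of 3-methylphenyl on an aromatic carbon. The two earlier swaps at the same place bear on it directly and were both small, so no step beyond the scatter is expected here either. Compound 4 is expected to give 15000 nM, within a range of 6000 nM to 40000 nM, which means an expected step of a 1.1-fold lower number from compound 3 to compound 4 (0.05 log units; within the scatter).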

Compound 4, half-maximal effective concentration: 18000 nM
Compound 4: middle estimate off by 1.2-fold (0.08 log units), on the low side; measured number inside the range.
By their numbers in this assay, from the lowest: compounds 2, 3, 4 and 1 (each within the scatter of the next).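

The fourth aryl group, 2-(methylamino)pyridin-4-yl, puts a hydrogen-bond donor at this position, which none of the earlier aryl groups offered, yet the numbers in this assay still do not separate (a 1.1-fold higher number from compound 3 to compound 4 (0.02 log units; within the scatter)) (a 1.3-fold higher number from compound 2 to compound 4 (0.11 log units; within the scatter)) (a 1.1-fold lower number from compound 1 to compound 4 (0.05 log units; within the scatter)). Across these four aryl groups, the choice of ring at this place makes no difference beyond the scatter. No measurement at hand explains this.

Still open, from the compounds shown here alone, is whether something other than an aryl group here, such as a morpholine ring or a plain hydrogen, would shift the number. Also open, going by these compounds, is what an amide in place of the neighbouring carboxy group would do.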